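The compounds below may be only part of what the source reports. "The series", "measured", "known", "first", "only" and "open" are said of these compounds alone.

Going by the values given here, compound 2 `C[C@@H](NC(=O)Nc1ccc(C(C)(C)C)cc1)c1ccccc1` gives 100% in an ADME assay on the whole organism with Oryza sativa as the target, tested at 0.1 uM (a higher number here means a weaker effect of the compound at the concentration tested, a lower number a stronger effect), one of only two numbers measured so far, and compound 1 `CCc1ccc(NC(=O)N[C@H](C)c2ccccc2)cc1` sits within the scatter of it at 95%. Compound 3 `CCCCc1ccc(NC(=O)N[C@H](C)c2ccccc2)cc1` has not yet been measured; it differs from compound 2 by butyl in place of tert-butyl on an aromatic carbon. Among the compounds with values here, the only measured step that bears on this, a number 5 percentage points higher from compound 1 to compound 2 (within the scatter), also exchanged the group on that aromatic carbon and stayed within the scatter, so nothing beyond the scatter is expected in this assay here either. The expected step is a number 3 percentage points lower from compound 2 to compound 3 (within the scatter). Compound 3 is therefore estimated at 97%, between 85% and 102%.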

Compound 3, a percentage reported as activity, at one concentration (the size of the read-out at that concentration, not a potency): 100%
For compound 3 the middle estimate is 3 percentage points below the measured one; the measured number falls inside the stated range.
By their numbers in this assay, from the lowest: compounds 1, 2 and 3 (each within the scatter of the next).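

In this assay, butyl in place of tert-butyl on this aromatic carbon, the same atoms joined differently, gives no change at the digits printed from compound 2 to compound 3 (within the scatter). Extending the ethyl chain to butyl gives a number 5 percentage points higher from compound 1 to compound 3 (within the scatter), so neither rearranging this group nor lengthening it moves the read-out beyond the scatter across these three compounds. No measurement here offers an explanation for this.

From the compounds shown here alone, whether a group of a different kind at this place, such as an amine or a carboxylic acid, would shift the number remains open. So does the effect of a chain longer than butyl.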